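The source may hold more compounds than are shown below. What is called first, only, known or untested is meant among the compounds shown, and "the series" means these compounds.

Of the compounds shown here, two have been measured in an assay on HEK293 cells for displacement of a labelled ligand from Melanocortin receptor 4 (Homo sapiens); a higher number here means a weaker inhibitor, a lower number a stronger inhibitor. Compound 1 `CC(C)C[C@H](NC(=O)CCN(C)C)c1cc(C(F)(F)F)ccc1N1CCN(C(=O)[C@H]2CSC[C@@H]2c2ccc(Cl)cc2)CC1` gives 130 nM. Compound 2 `CC(C)C[C@H](NCCN(C)C)c1cc(C(F)(F)F)ccc1N1CCN(C(=O)[C@H]2CS(=O)(=O)C[C@@H]2c2ccc(Cl)cc2)CC1` gives 170 nM in this assay; its number is the higher of the two, but the gap to compound 1 lies within the scatter, so the two cannot be told apart. Among the measured compounds shown here, compound 1 and compound 2 differ in more than one place: compound 1 carries a carbonyl on the amine nitrogen of its side chain where compound 2 carries the 2-(dimethylamino)ethyl group, and the two also differ elsewhere in the shared core, so no single step between them can be computed.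

Compound 3 `CNCC(=O)N[C@@H](CC(C)C)c1cc(C(F)(F)F)ccc1N1CCN(C(=O)[C@H]2CS(=O)(=O)C[C@@H]2c2ccc(Cl)cc2)CC1` has not yet been measured. It keeps everything of compound 2 except one group: ((methylamino)methyl)carbonyl in place of 2-(dimethylamino)ethyl on an amine nitrogen. For the measured compounds named here, no pair of measured compounds isolates this change. Compound 1 does show that a carbonyl at this nitrogen sits in the same range as compound 2, because compound 1 gives 130 nM. The step of a 1.3-fold lower number from compound 2 to compound 3 (0.12 log units; within the scatter) is therefore expected to stay within the scatter, with no clear direction. Compound 3 is estimated at 130 nM, with a range from 45 nM to 400 nM.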

Compound 3, inhibition constant: 180 nM
Compound 3: the middle estimate sits 1.4-fold (0.14 log units) below what was measured, and the stated range covers the measured number.
By their numbers in this assay, from the lowest: compounds 1, 2 and 3 (each within the scatter of the next).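

In this assay, replacing 2-(dimethylamino)ethyl with ((methylamino)methyl)carbonyl on this amine nitrogen gives a 1.1-fold higher number from compound 2 to compound 3 (0.02 log units; within the scatter) and leaves the two compounds indistinguishable. Compound 1 had already hinted that a carbonyl could sit on this nitrogen, but it also differs elsewhere in the shared core, whereas this pair isolates a single change and shows that swapping these two groups, with their different counts of hydrogen-bond donors and acceptors, produces no readable difference in this assay. Nothing measured here explains this result.

This single swap exchanges two chains of equal heavy-atom count, both ending in an amine, so it leaves open how the number would respond to a much shorter or longer chain on this nitrogen. It also leaves open whether the terminal amine matters at all, which a plain acetyl group or a carboxylic acid in its place would address, and whether the result would carry over to a core differing from that of compound 2 and compound 3.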